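Halogen Swap on the Anilide Ring of a Weak Inhibitor

The compounds below may be only part of what the source reports. "The series", "measured", "known", "first", "only" and "open" are said of these compounds alone.

Compound 2 `O=C(Cn1c(=O)c(/C=C\c2ccncc2)nc2ccccc21)Nc1ccc(F)cc1` carries a fluoro group on its anilide ring. Going by the values given here, in a functional assay on MCF7 cells (Homo sapiens) for inhibition, read by MTT assay, with a stated time of 24 h (a higher number here means a weaker inhibitor, a lower number a stronger inhibitor), compound 2 gives 49000 nM, the only number among the values shown here. Its parent, compound 1 `O=C(Cn1c(=O)c(/C=C\c2ccncc2)nc2ccccc21)Nc1ccccc1`, is known only from a limit of the assay: in this assay compound 1 gives > 100000 nM. The step of an at least 2.0-fold lower number from compound 1 to compound 2 (0.30 log units; that floor lies within the scatter) is therefore no more than a floor. What stands behind it is the limit of > 100000 nM in this assay, at which 1 of the 2 values shown sits. Compound 3 `O=C(Cn1c(=O)c(/C=C\c2ccncc2)nc2ccccc21)Nc1ccc(Cl)cc1` has not yet been measured. It differs from compound 2 by chloro in place of fluoro on an aromatic carbon. Among the compounds with values here, only the step from compound 1 to compound 2 bears on this swap, and it is a floor of unknown size, so the move from fluoro to chloro is expected to shift this assay by no more than the usual scatter, with a slight lean toward a lower number. For compound 3 the estimate in this assay is 35000 nM, between 12000 nM and 100000 nM. The step of a 1.4-fold lower number from compound 2 to compound 3 (0.15 log units; within the scatter) is what is expected.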

Compound 3, half-maximal inhibitory concentration: > 100000 nM
Compound 3: only a limit was reported; the forecaster's own chance of this, stated with the estimate: 20%; middle value at least 2.8-fold (0.45 log units) away from the limit.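

In this assay compound 3 gives > 100000 nM, which is a limit of the assay and not a number. Chloro in place of fluoro on this aromatic carbon, para to a large group, gives an at least 2.0-fold higher number from compound 2 to compound 3 (0.30 log units; that floor lies within the scatter), so the halogen swap did not carry the readable value over to the 4-chlorophenyl compound, and the 4-fluorophenyl group remains the only one here with a number, although the floor of this step does not go beyond the scatter. The step from compound 1 to compound 3 cannot be read, and the series now rests largely on a limit: the limit of > 100000 nM in this assay, at which 2 of the 3 values shown sit.

On these data alone, how far compound 1 and compound 3 lie past that limit remains open. So does what a methoxy group, an amine or a nitrile would give at this same position.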